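A Second Aryl Swap at the Same Ring Carbon

This account rests on a few compounds, and the source may have more. Where it says the series, first, only, none or still open, it means among the compounds named here.

For the measured compounds named here, compound 2 `CCc1ccc(-c2nc(CNc3ccc(C(=O)NO)cc3)n(-c3ccccc3)n2)cc1` stands higher than the only other compound measured in an assay on Sf9 cells for inhibition of protein deacetylase HDAC6 (Homo sapiens), read by fluorescence, with a stated time of 40 min, tested at 100 nM; a lower number here means less inhibition, a higher number more inhibition at the concentration tested (going by the name of the read-out): compound 2 gives 54.6%, while compound 1 `O=C(NO)c1ccc(NCc2nc(-c3cccc4cnccc34)nn2-c2ccccc2)cc1` gives 40.2%. Going by the values given here, the one measured step, a number 14.4 percentage points higher from compound 1 to compound 2 (beyond the scatter), lies beyond the scatter and comes from placing 4-ethylphenyl in place of isoquinolin-5-yl on an aromatic carbon. Compound 3 `O=C(NO)c1ccc(NCc2nc(-c3ccc(Cl)c(Cl)c3)nn2-c2ccccc2)cc1` alters the same place again: 3,4-dichlorophenyl in place of 4-ethylphenyl on an aromatic carbon. The measured step bears on this change only in that it touches the same aromatic carbon; it exchanged isoquinolin-5-yl for 4-ethylphenyl, whereas the present change trades one six-membered aromatic ring of carbon only for another, with 3,4-dichlorophenyl entering and 4-ethylphenyl leaving. Nothing measured shows how these two groups compare at this place, so no step beyond the scatter is expected in either direction, and the step of a number 4.6 percentage points lower from compound 2 to compound 3 (within the scatter) is estimated to be small. Compound 3 is therefore expected to give about 50% in this assay, with a range from 32% to 68% that allows for the uncertainty of an untested group.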

Compound 3, a percentage reported as inhibition, at one concentration (the size of the read-out at that concentration, not a potency): 34.5%
Compound 3: middle estimate off by 15.5 percentage points, on the high side; low and high end bracket the measured number.
By their numbers in this assay, from the lowest: compounds 3 and 1 (each within the scatter of the next); then compound 2.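

In this assay, for the compounds shown here, the step of a number 20.1 percentage points lower from compound 2 to compound 3 (beyond the scatter) shows that this aromatic carbon separates even two groups with the same count of heavy atoms and one six-membered aromatic ring of carbon only, so the earlier contrast between isoquinolin-5-yl and 4-ethylphenyl was not the only kind of change that registers here. The step of a number 5.7 percentage points lower from compound 1 to compound 3 (within the scatter) stays within the scatter, so 3,4-dichlorophenyl and isoquinolin-5-yl cannot be told apart at this place, although one carries two chlorine atoms and the other a ring nitrogen, and compound 2 with its 4-ethylphenyl alone stands beyond the scatter of both other compounds. No measurement offered here accounts for this difference between the groups.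

The compounds shown leave open whether the difference follows the ethyl group or the two chlorine atoms, which a plain phenyl, a 4-chlorophenyl or a 4-propylphenyl at this carbon would help to separate. They also leave open how a phenyl ring carrying an amine or a carboxylic acid would compare at the same place in this assay.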